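Ethyl to Isopropyl on a Thioester Near Adenosine Receptor Binding

A few compounds are considered here, and "the series" means these few. Any claim that something is new, unique, unknown or untested is made for them only; others in the source may bear on it.

Of the compounds shown here, three sharing one core have been tested in an assay on membranes from CHO cells for displacement of a labelled ligand from adenosine receptor A1 (Homo sapiens), read by scintillation counting, with a stated time of 60 min, tested at 1 uM; on this read-out lower numbers stand for less inhibition and higher numbers for more inhibition at the one concentration tested (going by the name of the read-out). Compound 1 `CC1=C(C(=O)NC(C)C)C(c2cccs2)NC(=O)N1` gives 2%. Compound 2 `CC1=C(C(=O)SC(C)C)C(c2ccco2)NC(=O)N1` gives 5%. Compound 3 `CCSC(=O)C1=C(C)NC(=O)NC1c1cccs1` gives 6%, the highest of the three numbers, yet its gaps to compound 2 and compound 1 both lie within the scatter, so no order among them can be read. For the measured compounds named here, the only single-point step, a number 4 percentage points higher from compound 1 to compound 3 (within the scatter), shows that swapping the group on the carbonyl carbon left the read-out essentially unchanged.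

Compound 4 `CC1=C(C(=O)SC(C)C)C(c2cccs2)NC(=O)N1` differs from compound 3 by methyl in place of hydrogen on a saturated chain carbon bound to a saturated chain carbon and a sulfur. This again alters only the group beyond the carbonyl. The step from compound 1 to compound 3 bears on it and was within the scatter; compound 2, which already carries the isopropylsulfanyl group, sits at a similar level. No step beyond the scatter is therefore expected in this assay: the expected step is a number 1 percentage points lower from compound 3 to compound 4 (within the scatter). Compound 4 is estimated at 5%, with a range from -5% to 15%.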

Compound 4, a percentage reported as inhibition, at one concentration (the size of the read-out at that concentration, not a potency): 1%
For compound 4 the middle estimate is 4 percentage points above the measured one; the range from low to high includes it.
By their numbers in this assay, from the lowest: compounds 4, 1, 2 and 3 (each within the scatter of the next).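

In this assay, the added methyl that turns ethylsulfanyl into isopropylsulfanyl gives a number 5 percentage points lower from compound 3 to compound 4 (within the scatter) and so does not separate the two compounds at this position. The other two single changes read the same way: thiophen-2-yl in place of furan-2-yl on a saturated ring carbon gives a number 4 percentage points lower from compound 2 to compound 4 (within the scatter) and exchanging the amide for the thioester gives a number 1 percentage points lower from compound 1 to compound 4 (within the scatter), so none of these three changes moves the read-out beyond the scatter. No further evidence bears on this result.

On these data alone, whether a longer chain or a benzyl group on the sulfur, or a carboxylic acid in place of the thioester, would give a clearly different number remains open. The compounds shown also leave open whether a primary amine on the carbonyl carbon would do so.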